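Trading 4-(trifluoromethyl)phenyl for 3-chlorophenyl on the carbonyl carbon

The compounds below may be only part of what the source reports. "The series", "measured", "known", "first", "only" and "open" are said of these compounds alone.

In a functional assay on a cell-free system (Platelet, plasma, Homo sapiens) for inhibition (on this read-out higher numbers stand for weaker inhibition and lower numbers for stronger inhibition), compound 2 (`Cc1ccc(N(CCN2CCC(OCC(=O)O)CC2)C(=O)c2ccc(C(F)(F)F)cc2)cc1`) stands at > 10000 nM, which is a limit and not a number. Compound 3 (`Cc1ccc(N(CCN2CCC(OCC(=O)O)CC2)C(=O)c2ccc(-c3ccccc3)cc2)cc1`) likewise gives only a limit, > 10000 nM. Among the compounds with values here, compound 1 (`Cc1ccc(N(CCN2CCC(OCC(=O)O)CC2)C(=O)c2ccc(Cl)cc2)cc1`) gives a measured number, 690 nM, and so is the only measured compound here with a readable potency.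

Compound 4 (`Cc1ccc(N(CCN2CCC(OCC(=O)O)CC2)C(=O)c2cccc(Cl)c2)cc1`) departs from compound 2 through (3-chlorophenyl in place of 4-(trifluoromethyl)phenyl on a carbonyl carbon). Within the data shown here, two measured steps bear on this change. They are an at least 14-fold higher number from compound 1 to compound 2 (1.16 log units; beyond the scatter) and an at least 14-fold higher number from compound 1 to compound 3 (1.16 log units; beyond the scatter), and both are large and lie beyond the scatter. In each, chloro gives way to another group and the number climbs to the limit. The third step, a step that the two limits leave unreadable from compound 2 to compound 3, adds nothing.

Compound 4 carries chloro, as does compound 1 at 690 nM, so a return toward stronger inhibition is expected. Among the measured compounds shown here, no measured compound here holds the 3-chlorophenyl group, however, so the full recovery is not assured, and a limit remains possible. The expected change, clearly beyond the scatter and toward a lower number, is an at least 5.0-fold lower number from compound 2 to compound 4 (0.69 log units; beyond the scatter). Compound 4 is estimated at 2000 nM, with an expected range from 500 nM to 10000 nM.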

Compound 4, half-maximal inhibitory concentration: 100 nM
The estimate for compound 4 lay 20-fold (1.30 log units) above the measured number; the measured number lies below the stated range.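

In this assay, trading 4-chlorophenyl for 3-chlorophenyl on a carbonyl carbon gives a 6.9-fold lower number from compound 1 to compound 4 (0.84 log units; beyond the scatter), so where the chloro sits on this ring matters as well as whether chloro is present, something compound 1, compound 2 and compound 3 could not show, since they varied only the group and not its placing. The change from 4-(trifluoromethyl)phenyl to 3-chlorophenyl gives an at least 100-fold lower number from compound 2 to compound 4 (2.00 log units; beyond the scatter), but this step alters the group and its placing together, so on its own it cannot assign the gain to either. Compound 2 gives only a limit, so the size of that step is a lower bound: the limit of > 10000 nM in this assay, at which 2 of the 4 values shown sit.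

The compounds shown leave open whether the gain belongs to chloro itself or would also appear with 3-(trifluoromethyl)phenyl, 3-fluorophenyl or 3-methoxyphenyl in the same place on the carbonyl carbon. They also leave open whether a dichlorophenyl group, carrying chloro in both placings, would add to or lose the gain seen with compound 4.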